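From ester to 2-hydroxypropyl ether: working notes on the series

The source may report more compounds than this note shows. Statements on the series, on what has been measured and on what is new or still open speak of the compounds shown alone.

Within the data shown here, in a functional assay on HeLa cells (Homo sapiens) for cytotoxicity, read by MTT assay (a lower number here means a stronger inhibitor, a higher number a weaker inhibitor), compound 1 (`CC(C)=CC[C@@H](OC(=O)c1ccco1)C1=CC(=O)c2c(O)ccc(O)c2C1=O`) gives 80300 nM and compound 2 (`CC[C@](C)(O)CC(=O)O[C@H](CC=C(C)C)C1=CC(=O)c2c(O)ccc(O)c2C1=O`) gives 30200 nM as the lower of the two numbers so far. Compound 3 (`CC(C)=CC[C@@H](OCC(C)O)C1=CC(=O)c2c(O)ccc(O)c2C1=O`) carries 2-hydroxypropyl in place of (2-hydroxy-2-methylbutyl)carbonyl on an oxygen on a saturated carbon and has not yet been measured. Among the measured compounds shown here, only one measured step bears on this change, namely a 2.7-fold lower number from compound 1 to compound 2 (0.42 log units; beyond the scatter) for 2-hydroxy-2-methylbutyl in place of furan-2-yl on a carbonyl carbon, and it is modest. Neither measured compound carries 2-hydroxypropyl, so that step offers a rough scale and no direction. In this assay a shift no larger than that modest step is therefore expected, most likely none beyond the scatter, with the direction left open. For the measured compounds named here, the estimated change is a 1.2-fold higher number from compound 2 to compound 3 (0.06 log units; within the scatter) and remains uncertain with only two measured compounds. In this assay the expected value for compound 3 is 35000 nM with a range of 12000 nM to 90000 nM as estimated here.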

Compound 3, half-maximal inhibitory concentration: 24700 nM
Compound 3: middle estimate off by 1.4-fold (0.15 log units), on the high side, within the range that was stated.
By their numbers in this assay, from the lowest: compounds 3 and 2 (each within the scatter of the next); then compound 1.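

In this assay the change at this oxygen on a saturated carbon leaves the number within the scatter, a 1.2-fold lower number from compound 2 to compound 3 (0.09 log units; within the scatter), even though 2-hydroxypropyl has 4 heavy atoms where (2-hydroxy-2-methylbutyl)carbonyl has 8. Compound 1 and compound 2 both carry a carbonyl on this oxygen, so they could not show what this one does: with that carbonyl gone and an ether in its place, compound 3 still stands level with compound 2. Among these compounds, the distance from the furan ester is also kept, a 3.3-fold lower number from compound 1 to compound 3 (0.51 log units; beyond the scatter), so compound 2 and compound 3 both stand apart from compound 1, and (furan-2-yl)carbonyl remains the one group here that gives a higher number beyond the scatter.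

Still open, going by these compounds, is whether the hydroxyl of 2-hydroxypropyl counts at all, which a plain propyl group on the same oxygen would address, and whether an amine or a carboxylic acid on that chain would move the number beyond the scatter. On these data alone, the 2-hydroxypropyl of compound 3 has no defined stereocentre, so the two separate forms at that carbon also remain open.

Nothing given here offers an explanation for these numbers.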